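The compounds below may be only part of what the source reports. "The series", "measured", "known", "first", "only" and "open" are said of these compounds alone.

Measured compounds:
compound 1, `O=[N+]([O-])c1ccccc1CSc1nnc(-c2ccc3c(c2)OCCO3)n1-c1ccccc1`, gives 69800 nM in a functional assay on HeLa cells (Homo sapiens) for antiproliferative activity, read by MTT assay, with a stated time of 24 h; a lower number here means a stronger inhibitor, a higher number a weaker inhibitor.
compound 2, `Cc1ccc(CSc2nnc(-c3ccc4c(c3)OCCO4)n2-c2ccccc2)cc1`, gives 49700 nM in this assay.

Going by the values given here, compound 2 has the lowest of the two numbers so far, with compound 1 nearest to it; the step of a 1.4-fold lower number from compound 1 to compound 2 (0.15 log units; within the scatter) lies within the scatter, so the two compounds cannot be told apart on these numbers. Compound 3, `Fc1ccc(CSc2nnc(-c3ccc4c(c3)OCCO4)n2-c2ccccc2)cc1`, differs from compound 2 only at the far end of the benzyl group: fluoro in place of methyl on an aromatic carbon. Among the compounds with values here, the one measured step that bears on this change is the one at the same position, from compound 1 to compound 2, where a 2-nitrophenyl became a 4-methylphenyl and the number barely moved, as a 1.4-fold lower number from compound 1 to compound 2 (0.15 log units; within the scatter) shows. Within the data shown here, with only that step in hand, and it within the scatter, no step beyond the scatter is expected for compound 3 in this assay in either direction; the expected step of a 1.0-fold higher number from compound 2 to compound 3 (0.00 log units; within the scatter) is therefore small. Compound 3 is thus estimated at 50000 nM in this assay, with a range from 25000 nM to 100000 nM.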

Compound 3, half-maximal inhibitory concentration: 46900 nM
The estimate for compound 3 lay 1.1-fold (0.03 log units) above the measured number; low and high end bracket the measured number.
By their numbers in this assay, from the lowest: compounds 3, 2 and 1 (each within the scatter of the next).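

In this assay, placing fluoro where methyl stood on the aromatic carbon, para to a large group, gives a 1.1-fold lower number from compound 2 to compound 3 (0.03 log units; within the scatter), so this exchange of one heavy atom for another leaves the two compounds indistinguishable on these numbers. The step from the 2-nitrophenyl group to the 4-fluorophenyl group gives a 1.5-fold lower number from compound 1 to compound 3 (0.17 log units; within the scatter), which means that all three benzyl variants now shown, the 2-nitrophenyl, the 4-methylphenyl and the 4-fluorophenyl, lie within the scatter of one another, and this position has not yet yielded a step that can be told from noise. No measurement at hand offers an explanation for this lack of separation.

Going by these compounds, all three compounds share the same core and differ only in the group on the benzyl ring, so it remains open whether an amine or a carboxylic acid on that ring, or a longer chain in place of the benzyl group, would produce a step beyond the scatter. On these data alone, it also remains open whether a substituent on the phenyl group attached to the core, such as a methoxy group, would do so.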